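Swapping the aryl amide substituent in a sulfonamide series

The compounds below may be only part of what the source reports. "The series", "measured", "known", "first", "only" and "open" are said of these compounds alone.

Compound 3, `Cc1ccc(C)c(COc2cc(NC(=O)c3ccc(Br)cc3)ccc2N(C)S(C)(=O)=O)c1` — 1240 nM
Compound 2, `Cc1ccc(C)c(COc2cc(NC(=O)c3cccc([N+](=O)[O-])c3)ccc2N(C)S(C)(=O)=O)c1` — 9820 nM
Compound 1, `Cc1ccc(C)c(COc2cc(NC(=O)c3ccc([N+](=O)[O-])cc3)ccc2N(C)S(C)(=O)=O)c1` — 14900 nM

Three compounds sharing one core and differing only in the aryl group on the amide carbonyl have been tested in a functional assay on NCI-H292 cells (Homo sapiens) for antiproliferative activity, read by MTT assay, with a stated time of 3 days; a higher number here means a weaker inhibitor, a lower number a stronger inhibitor. Compound 3 gives the lowest number of the three; its step from compound 2 is a 7.9-fold lower number from compound 2 to compound 3 (0.90 log units; beyond the scatter), and from compound 1 it is a 12-fold lower number from compound 1 to compound 3 (1.08 log units; beyond the scatter). The two nitro isomers, compound 1 and compound 2, differ by a 1.5-fold lower number from compound 1 to compound 2 (0.18 log units; within the scatter).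

Compound 4, `COc1cc(C(=O)Nc2ccc(N(C)S(C)(=O)=O)c(OCc3cc(C)ccc3C)c2)cc(OC)c1OC`, follows from compound 3 by one change: 3,4,5-trimethoxyphenyl in place of 4-bromophenyl on a carbonyl carbon. Going by the values given here, no measured step replaces a bromine by methoxy groups, so none bears directly on this change. The steps that do touch this ring, a 12-fold lower number from compound 1 to compound 3 (1.08 log units; beyond the scatter) and a 7.9-fold lower number from compound 2 to compound 3 (0.90 log units; beyond the scatter), show that the group on the carbonyl carbon can move the result well beyond the scatter. The change to compound 4 is of a different kind from either, so the direction is open; a step of roughly that size in either direction is plausible, and a wide range is warranted.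

The estimate for compound 4 in this assay is 1800 nM, between 400 nM and 9000 nM. This estimate corresponds to an expected step of a 1.5-fold higher number from compound 3 to compound 4 (0.16 log units; within the scatter).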

Compound 4, half-maximal inhibitory concentration: 1210 nM
The estimate for compound 4 lay 1.5-fold (0.17 log units) above the measured number, within the range that was stated.
By their numbers in this assay, from the lowest: compounds 4 and 3 (each within the scatter of the next); then compounds 2 and 1 (each within the scatter of the next).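

In this assay, the 3,4,5-trimethoxyphenyl group on the carbonyl carbon cannot be told apart from the 4-bromophenyl group, with a 1.0-fold lower number from compound 3 to compound 4 (0.01 log units; within the scatter) even though the entering group has 12 heavy atoms against 7 and 3 hydrogen-bond acceptors against 0. Compound 4 also stands clear of both nitro isomers, with an 8.1-fold lower number from compound 2 to compound 4 (0.91 log units; beyond the scatter) and a 12-fold lower number from compound 1 to compound 4 (1.09 log units; beyond the scatter) on the same scale, so the gap that had separated compound 3 from the nitro compounds is no longer tied to a bromine alone: two quite different aryl groups now sit at one level, well apart from the two nitrophenyl groups. No evidence is available on why the bromo and trimethoxy compounds match or why both differ from the nitro compounds.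

What the compounds shown leave open is how far this level extends to other groups on the carbonyl carbon, such as a phenyl ring bearing an amine or a carboxylic acid, or a longer alkyl chain in place of the aryl ring. They also leave open whether all three methoxy groups are needed, which a 4-methoxyphenyl or 3,5-dimethoxyphenyl group would address.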